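Sulfonamide variation on the shared core: step to compound 4

The source may hold more compounds than are shown below. What is called first, only, known or untested is meant among the compounds shown, and "the series" means these compounds.

Measured so far in an assay on isolated protein for inhibition of high affinity nerve growth factor receptor (Homo sapiens), read by 33P incorporation; a lower number here means a stronger inhibitor, a higher number a weaker inhibitor:
compound 1 `Nc1cc(NS(=O)(=O)c2ccc(F)cc2F)cc(-c2cnc3[nH]cc(-c4ccncc4)c3c2)c1` gives 2.97 nM
compound 2 `Nc1cc(NS(=O)(=O)c2ccccc2)cc(-c2cnc3[nH]cc(-c4ccncc4)c3c2)c1` gives 9.4 nM
compound 3 `CS(=O)(=O)Nc1cc(N)cc(-c2cnc3[nH]cc(-c4ccncc4)c3c2)c1` gives 33.8 nM

Compound 3 stands highest of the three numbers in this assay, a 3.6-fold higher number from compound 2 to compound 3 (0.56 log units; beyond the scatter) and an 11-fold higher number from compound 1 to compound 3 (1.06 log units; beyond the scatter). Compound 4 `Cc1ccc(S(=O)(=O)Nc2cc(N)cc(-c3cnc4[nH]cc(-c5ccncc5)c4c3)c2)cc1` differs from compound 3 by 4-methylphenyl in place of methyl on a sulfonyl sulfur. The step that bears most directly is a 3.6-fold higher number from compound 2 to compound 3 (0.56 log units; beyond the scatter), which runs the opposite way to the present change; both steps that replace an aryl sulfonyl with methyl raise the number, so an aryl group entering in place of methyl is expected to lower it by a modest amount, roughly undoing that step. Compound 4 is therefore estimated at 9 nM, between 3 nM and 25 nM, an expected 3.8-fold lower number from compound 3 to compound 4 (0.57 log units; beyond the scatter).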

Compound 4, half-maximal inhibitory concentration: 4.62 nM
Compound 4: middle estimate off by 1.9-fold (0.29 log units), on the high side; the measured number falls inside the stated range.
By their numbers in this assay, from the lowest: compounds 1 and 4 (each within the scatter of the next); then compound 2; then compound 3.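

In this assay, an aryl group on the sulfonyl sulfur gains more than phenyl alone had shown (a 7.3-fold lower number from compound 3 to compound 4 (0.86 log units; beyond the scatter)), and the methyl added to phenyl gives a further step beyond the scatter (a 2.0-fold lower number from compound 2 to compound 4 (0.31 log units; beyond the scatter)). 4-Methylphenyl and 2,4-difluorophenyl cannot be separated (a 1.6-fold higher number from compound 1 to compound 4 (0.19 log units; within the scatter)), so in these compounds a lower number than phenyl's does not depend on fluorine. Nothing available explains these differences. Still open, as far as these compounds go, is how an amine or carboxylic acid on the phenyl ring would compare. From the compounds shown here alone, a longer chain in place of methyl on the sulfonyl sulfur also remains open.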